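Side-chain exchange from compound 3 to compound 4

The compounds below may be only part of what the source reports. "The series", "measured", "known", "first", "only" and "open" are said of these compounds alone.

In a functional assay on BV-2 cells (Mus musculus), read by Griess assay, with a stated time of 24 h (on this read-out lower numbers stand for stronger inhibition and higher numbers for weaker inhibition), compound 1 (`CC1COC2(C=CC(=O)C=C2)N(c2ccccc2)C1=O`) gives 1220 nM and compound 2 (`C=CCCC1COC2(C=CC(=O)C=C2)N(c2ccccc2)C1=O`) gives 730 nM with compound 3 (`O=C1C=CC2(C=C1)OCC(Cc1cccc(Br)c1)C(=O)N2c1ccccc1`) at 540 nM in the same series. Compound 3 stands beyond the scatter from compound 1 and within it from compound 2. Compound 4 (`O=C1C=CC2(C=C1)OCC(Cc1ccc(C(F)(F)F)cc1)C(=O)N2c1ccccc1`) carries 4-(trifluoromethyl)phenyl in place of 3-bromophenyl on a saturated chain carbon bound to a saturated ring carbon. Three measured steps at this place bear on it: allyl in place of hydrogen gave a 1.7-fold lower number from compound 1 to compound 2 (0.22 log units; within the scatter) and 3-bromophenyl in place of hydrogen gave a 2.3-fold lower number from compound 1 to compound 3 (0.35 log units; beyond the scatter) while 3-bromophenyl in place of allyl gave a 1.4-fold lower number from compound 2 to compound 3 (0.13 log units; within the scatter) at most modestly. Among the compounds with values here, no measured step covers a trifluoromethyl group. No change beyond the scatter is therefore expected in this assay, the estimated step being a 1.1-fold lower number from compound 3 to compound 4 (0.03 log units; within the scatter) in size. Compound 4 is estimated at 500 nM (expected range 210 nM to 1200 nM).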

Compound 4, half-maximal inhibitory concentration: 1650 nM
The estimate for compound 4 lay 3.3-fold (0.52 log units) below the measured number, and the stated range ends below it.
By their numbers in this assay, from the lowest: compounds 3, 2, 1 and 4 (each within the scatter of the next, the first and the last beyond it).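

In this assay an aromatic ring at this place does not by itself go with a lower number: 4-(trifluoromethyl)phenyl gives a 3.1-fold higher number from compound 3 to compound 4 (0.49 log units; beyond the scatter) and a 2.3-fold higher number from compound 2 to compound 4 (0.35 log units; beyond the scatter) and, against hydrogen, only a 1.4-fold higher number from compound 1 to compound 4 (0.13 log units; within the scatter) here. The drop seen with 3-bromophenyl therefore does not carry over to every substituted phenyl. No evidence on the cause of this step is at hand. Compound 3 and compound 4 differ in both the substituent and its place on the ring, so the two effects cannot be separated. On these data alone, how a plain phenyl, or a phenyl bearing an amine or a carboxylic acid, would behave remains open.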